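A few compounds are considered here, and "the series" means these few. Any claim that something is new, unique, unknown or untested is made for them only; others in the source may bear on it.

Compound 1, `c1ccc(-c2nc3cccnc3n2C2CCCC2)cc1`: 3000 nM
Compound 2, `Fc1cc(F)cc(-c2nc3cccnc3n2C2CCCC2)c1`: 138 nM
Compound 3, `Cc1cccc(-c2nc3cccnc3n2C2CCCC2)c1Cl`: 646 nM

Of the compounds shown here, three sharing one core have been tested in a functional assay on MDA-MB-231 cells (Homo sapiens) for cytotoxicity, read by MTT assay, with a stated time of 24 h; on this read-out higher numbers stand for weaker inhibition and lower numbers for stronger inhibition. Compound 1 carries an unsubstituted phenyl ring and gives 3000 nM, the highest number of the three, so it is the weakest inhibitor in this set. Compound 3 gives 646 nM and compound 2 gives 138 nM; both lie well beyond the scatter from compound 1, so adding groups to the phenyl ring of compound 1 has in each case brought the number down.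

The next compound, compound 4, `CN(C)C(=O)c1ccc(-c2nc3cccnc3n2C2CCCC2)cc1`, takes a different route. Relative to compound 1 the change is dimethylcarbamoyl in place of hydrogen on an aromatic carbon, with the new group sitting on an aromatic carbon of a six-membered aromatic ring of carbon only, para to a large group. Within the data shown here, no directly comparable pair of measured compounds exists for this change, so the expectation can rest only on the observation that every substituted phenyl so far has given a lower number than compound 1. The step in this assay is therefore expected to be downward, though of uncertain size, and a result within the scatter cannot be ruled out. The estimated step from compound 1 to compound 4 is a 2.0-fold lower number from compound 1 to compound 4 (0.30 log units; within the scatter). Compound 4 is thus expected to give about 1500 nM, with a likely range from 400 nM to 5000 nM.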

Compound 4, half-maximal inhibitory concentration: 520 nM
Compound 4: middle estimate off by 2.9-fold (0.46 log units), on the high side; the measured number falls inside the stated range.
By their numbers in this assay, from the lowest: compound 2; then compounds 4 and 3 (each within the scatter of the next); then compound 1.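

Compound 2 and compound 3 each differ from compound 1 in more than one place on the phenyl ring, so neither could show what a single group does on its own. In this assay, dimethylcarbamoyl in place of hydrogen, on the aromatic carbon para to a large group, now gives a 5.8-fold lower number from compound 1 to compound 4 (0.76 log units; beyond the scatter), so this one change at this one position is enough to move the number beyond the usual scatter. Nothing given here explains why the number falls.

As far as these compounds go, one group at one position cannot show which part of dimethylcarbamoyl matters, so it remains open whether a carboxylic acid, a methyl ester or an unsubstituted amide on the same aromatic carbon would give a similar step. From the compounds shown here alone, it is also open whether dimethylcarbamoyl would have the same effect at another carbon of the phenyl ring, or whether a simple fluorine or chlorine at the position para to a large group would lower the number as well.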